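A few compounds are considered here, and "the series" means these few. Any claim that something is new, unique, unknown or untested is made for them only; others in the source may bear on it.

Three compounds were tested in a functional assay on K562/Adr cells (Homo sapiens) for inhibition, read by MTT assay, with a stated time of 48 h, tested at 30 uM; a lower number here means less inhibition, a higher number more inhibition at the concentration tested (going by the name of the read-out). Compound 1 `O=C(Nc1n[nH]c2cc(-c3cn([C@@H]4CN[C@H](C(=O)Nc5ccc(Cl)cc5Cl)C4)nn3)ccc12)C1CC1` gives 43.3%. Compound 2 `O=C(Nc1n[nH]c2cc(-c3cn([C@@H]4CN[C@H](C(=O)Nc5ccc(Br)cc5)C4)nn3)ccc12)C1CC1` gives 39.6%. Compound 3 `Nc1nc2ccc(-c3cn([C@@H]4CN[C@H](C(=O)Nc5ccc(Cl)cc5Cl)C4)nn3)nc2s1` gives 42.2%.

Compound 1 and compound 2 share one core and differ in a single place: 4-bromophenyl in place of 2,4-dichlorophenyl on an amide-type nitrogen. In this assay the step of a number 3.7 percentage points lower from compound 1 to compound 2 (within the scatter). Compound 3 is built on a different core, and the difference between the two cores is not broken down here; the values of compound 1 and compound 3 lie within the scatter of each other.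

Compound 4 `Nc1nc2ccc(-c3cn([C@@H]4CN[C@H](C(=O)Nc5ccc(Br)cc5)C4)nn3)nc2s1` has not yet been measured. It stands to compound 3 as compound 2 stands to compound 1, and the change is the same: 4-bromophenyl in place of 2,4-dichlorophenyl on an amide-type nitrogen. Within the data shown here, with only one earlier example of this change to go on, the expected step is a number 3.7 percentage points lower from compound 3 to compound 4 (within the scatter), estimated from the measured step of a number 3.7 percentage points lower from compound 1 to compound 2 (within the scatter) on the other core. Compound 4 is therefore expected to give about 38.5% in this assay, most likely between 28% and 49%.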

Compound 4, a percentage reported as inhibition, at one concentration (the size of the read-out at that concentration, not a potency): 35.9%
Estimate against measurement, compound 4: 2.6 percentage points above; low and high end bracket the measured number.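

On the core of compound 3, putting 4-bromophenyl in place of 2,4-dichlorophenyl on the amide-type nitrogen gives a number 6.3 percentage points lower from compound 3 to compound 4 (within the scatter) in this assay. Set beside the earlier example, the two cores give no distinguishable result for this change: the same change on two cores in this assay, a number 3.7 percentage points lower (within the scatter) from compound 1 to compound 2 and a number 6.3 percentage points lower (within the scatter) from compound 3 to compound 4, 2.6 percentage points apart, within the scatter of two such steps

The change therefore carries across these two cores without any sign that the core alters its outcome, but both steps lie within the scatter, so these pairs do not show that the change has a real effect of its own, and two pairs say nothing about any further core.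

All the aryl groups shown on the amide-type nitrogen carry halogens, so it remains open how an unsubstituted phenyl, a methoxyphenyl or a non-aromatic group such as cyclohexyl would behave there. Going by these compounds, a group carrying an amine or a carboxylic acid at this position is equally open, and any of these might show a step that stands clear of the scatter.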